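Fluoro in Place of Nitro: Expected Loss of Cytotoxic Potency

A few compounds are considered here, and "the series" means these few. Any claim that something is new, unique, unknown or untested is made for them only; others in the source may bear on it.

Three compounds were measured in a functional assay on CCRF-CEM cells (Homo sapiens) for cytotoxicity, in the absence of a further agent; on this read-out lower numbers stand for stronger inhibition and higher numbers for weaker inhibition:

Compound 1, `CC(C)(C)OC(=O)CCC(Nc1ccc(CN(CCCc2c(N)nc(N)nc2O)c2ccc([N+](=O)[O-])c(F)c2[N+](=O)[O-])cc1)C(=O)OC(C)(C)C`: 3900 nM
Compound 2, `Nc1nc(N)c(CCCNc2cc(F)c([N+](=O)[O-])cc2[N+](=O)[O-])c(O)n1`: 1000 nM
Compound 3, `CC(C)(C)OC(=O)CCC(Nc1ccc(CN(CCCc2c(N)nc(N)nc2O)c2ccc([N+](=O)[O-])c(F)c2F)cc1)C(=O)OC(C)(C)C`: 20000 nM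

Compound 1 and compound 3 differ in one place, (fluoro in place of nitro on an aromatic carbon), and that change gave a 5.1-fold higher number from compound 1 to compound 3 (0.71 log units; beyond the scatter). Compound 2 carries a different core; how the core of compound 2 differs from that of compound 1 is not broken down here. Its number is the lowest of the three, with compound 1 nearer to it and compound 3 furthest away.

Compound 4, `Nc1nc(N)c(CCCNc2cc(F)c(F)cc2[N+](=O)[O-])c(O)n1`, is not yet measured. It arises from compound 2 by fluoro in place of nitro on an aromatic carbon. The surroundings are not identical: in compound 1 the altered carbon is ortho to a large group, whereas in compound 2 it is para to a large group, so this is the same kind of change rather than the same change. The step expected for compound 4, a 5.0-fold higher number from compound 2 to compound 4 (0.70 log units; beyond the scatter), rests on the same kind of change having given a 5.1-fold higher number from compound 1 to compound 3 (0.71 log units; beyond the scatter). For compound 4 the estimated value is 5000 nM, expected to lie between 1500 nM and 20000 nM.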

Compound 4, half-maximal inhibitory concentration: 97000 nM
The estimate for compound 4 lay 19-fold (1.29 log units) below the measured number; measured number above the stated range.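

Replacing nitro with fluoro on an aromatic carbon of compound 2 gave a 97-fold higher number from compound 2 to compound 4 (1.99 log units; beyond the scatter) in this assay and so moved the number in the same direction as on the core of compound 1, but much further. The direction of this change is therefore shared by the two pairs shown, while its size does not carry over from one core to the other: the same change on two cores in this assay, a 5.1-fold higher number (0.71 log units; beyond the scatter) from compound 1 to compound 3 and a 97-fold higher number (1.99 log units; beyond the scatter) from compound 2 to compound 4, 19-fold (1.28 log units) apart, beyond the scatter of two such steps. This does not show which part of the cores sets the size of the step, as the cores differ in more than one place and the surroundings of the altered carbon differ too, and two pairs give no rule for a third core.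

From the compounds shown here alone, it remains open whether a hydrogen, an amine or a nitrile on that same carbon would behave like fluoro. Also open, going by these compounds, is how the step would look on compound 1 with its two esters replaced by free carboxylic acids, or on compound 2 with a longer chain.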